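Removing an aromatic hydroxy in the shared core

The source may hold more compounds than are shown below. What is called first, only, known or untested is meant among the compounds shown, and "the series" means these compounds.

Of the compounds shown here, three of the shared core have been measured in an assay on isolated protein for inhibition of alpha-mannosidase (Canavalia ensiformis), tested at 1000 uM; a lower number here means less inhibition, a higher number more inhibition at the concentration tested (going by the name of the read-out). Compound 1 `OC[C@]1(c2ccc(F)cc2)NC[C@H](O)[C@H]1O` gives 6.6%, compound 2 `OC[C@@]1(c2ccc(O)cc2)NC[C@@H](O)[C@@H]1O` gives 2.2%, and compound 3 `C[C@]1(CO)NC[C@@H](O)[C@@H]1O` gives 3.8%. The number for compound 2 is separated from those of compound 3 and compound 1 only by amounts within the scatter, so compound 2 stands with the other two as one group of weak inhibition. Compound 4 `OC[C@@]1(c2ccccc2)NC[C@@H](O)[C@@H]1O` has not been measured. It differs from compound 2 by hydrogen in place of hydroxy on an aromatic carbon. Going by the values given here, no step between measured compounds gauges such a change, and all three measured numbers sit near the floor of the read-out. The step of a number 1.8 percentage points higher from compound 2 to compound 4 (within the scatter) is therefore expected to stay within the scatter, in no clear direction. Compound 4 is estimated at 4%, within a range from 0% to 12%.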

Compound 4, a percentage reported as inhibition, at one concentration (the size of the read-out at that concentration, not a potency): 0%
The estimate for compound 4 lay 4 percentage points above the measured number; the range from low to high includes it.
By their numbers in this assay, from the lowest: compounds 4, 2, 3 and 1 (each within the scatter of the next).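

Hydrogen in place of hydroxy on an aromatic carbon, para to a group of 9 heavy atoms, gives a number 2.2 percentage points lower from compound 2 to compound 4 (within the scatter) in this assay and is the first step to gauge this position. Compound 4 gives 0%, so the hydroxy shows no measurable contribution at the concentration tested, though a number of this size leaves little room to detect one.

On these data alone, whether an amine or a carboxylic acid on this aromatic carbon would lift the number clear of the floor remains open. No measurement at hand offers a reason for this reading.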